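Methoxy for methyl on the benzyl ring of compound 2

A few compounds are considered here, and "the series" means these few. Any claim that something is new, unique, unknown or untested is made for them only; others in the source may bear on it.

Compound 2 `COc1cc(N(Cc2ccc(C)cc2)C(=O)CSc2nc3ccccc3s2)cc(OC)c1OC` carries a 4-methylbenzyl group on the amide nitrogen. In a functional assay on PC-3 cells (Homo sapiens) for antiproliferative activity, read by MTT assay, with a stated time of 48 h (a higher number here means a weaker inhibitor, a lower number a stronger inhibitor), compound 2 gives only a limit, > 80000 nM; the value is a limit of the assay and not a number, and the limit of > 80000 nM in this assay, at which 1 of the 3 values shown sits, describes where it sits among the values shown. Compound 4 `COc1ccc(CN(C(=O)CSc2nc3ccccc3s2)c2cc(OC)c(OC)c(OC)c2)cc1` is the analog in which the change is methoxy in place of methyl on an aromatic carbon. The two other measured compounds differ from compound 4 in more than one place. Compound 1 `COc1ccc(CN(C(=O)CSc2nc3cc(Br)ccc3s2)c2cc(OC)c(OC)c(OC)c2)cc1O` gives 8210 nM in this assay. Compound 3 `COc1ccc(CN(C(=O)CSc2nc3c(C)cccc3s2)c2cc(OC)c(OC)c(OC)c2)cc1O` gives 12300 nM in this assay, and a 1.5-fold higher number from compound 1 to compound 3 (0.18 log units; within the scatter) shows that the substituent on the benzothiazole part of the shared core barely moves the result. Within the data shown here, no measured pair isolates methoxy against methyl on the benzyl ring, so the size of the step from compound 2 to compound 4 cannot be read from a measured step. Compounds 1 and 3, which carry a methoxy-bearing benzyl group, do return numbers, so compound 4 is expected to fall between their values and the limit. Compound 4 is therefore expected at 30000 nM in this assay, with a range from 9000 nM to 80000 nM. The expected step of an at least 2.6-fold lower number from compound 2 to compound 4 (0.42 log units; beyond the scatter) is toward a stronger inhibitor, though a limit remains possible.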

Compound 4, half-maximal inhibitory concentration: 8460 nM
For compound 4 the middle estimate is 3.5-fold (0.55 log units) above the measured one; measured number below the stated range.
By their numbers in this assay, from the lowest: compounds 1, 4 and 3 (each within the scatter of the next). At a limit, above all of these: compound 2.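

In this assay, among these compounds, the change from 4-methylbenzyl to 4-methoxybenzyl gives an at least 9.4-fold lower number from compound 2 to compound 4 (0.97 log units; beyond the scatter), the first reading of a single change on this ring, at the aromatic carbon para to a large group. Among the compounds shown here, the one earlier step, a 1.5-fold higher number from compound 1 to compound 3 (0.18 log units; within the scatter), concerned a substituent elsewhere on the shared core and stayed within the scatter, so this position is the first place where one change separates a compound with a measured number from one without. The size of the step remains a minimum, as compound 2 has a limit of the assay and not a number: the limit of > 80000 nM in this assay, at which 1 of the 4 values shown sits.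

The compounds shown do not tell whether the added oxygen or the longer group carries the step, and an ethyl group at the same position would separate the two. Nor do they show whether other groups here, such as an amine or a carboxylic acid, keep the number of compound 4 or lose it, or whether the step holds with other substituents on the shared core.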